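Adding a chloro to compound 2

A few compounds are considered here, and "the series" means these few. Any claim that something is new, unique, unknown or untested is made for them only; others in the source may bear on it.

- compound 1 `O=C(Nc1cccc(-n2cc(-c3ccncc3)c(-c3ccc(Cl)c(O)c3)n2)c1)Nc1cccc(C(F)(F)F)c1`: 2230 nM
- compound 2 `COc1cc(-c2nn(-c3cccc(NC(=O)c4cccc(C(F)(F)F)c4)c3)cc2-c2ccncc2)ccc1Cl`: 3120 nM

In a functional assay on HOP-92 cells (Homo sapiens) for inhibition, read by sulforhodamine B assay, with a stated time of 48 h (on this read-out lower numbers stand for stronger inhibition of growth and higher numbers for weaker inhibition of growth), compound 2 lies within the usual scatter of compound 1, so the two values cannot be told apart. Compound 3 `COc1cc(-c2nn(-c3cccc(NC(=O)c4ccc(Cl)c(C(F)(F)F)c4)c3)cc2-c2ccncc2)ccc1Cl` has chloro in place of hydrogen on an aromatic carbon, turning the 3-(trifluoromethyl)phenyl of compound 2 into 4-chloro-3-(trifluoromethyl)phenyl (chloro in place of hydrogen on an aromatic carbon). The new chloro sits ortho to a trifluoromethyl group and para to a large group. Among the measured compounds shown here, no measured pair here shows this change, so the expectation is tentative. Nothing beyond the scatter is expected, with a slight lean to a lower number: the estimated step is a 1.2-fold lower number from compound 2 to compound 3 (0.10 log units; within the scatter). Compound 3 is estimated at 2500 nM, within a range of 1100 nM to 5500 nM.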

Compound 3, concentration for total growth inhibition: 3230 nM
Compound 3: the middle estimate sits 1.3-fold (0.11 log units) below what was measured; low and high end bracket the measured number.
By their numbers in this assay, from the lowest: compounds 1, 2 and 3 (each within the scatter of the next).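

Replacing hydrogen with chloro to give the 4-chloro-3-(trifluoromethyl)phenyl group produces a 1.0-fold higher number from compound 2 to compound 3 (0.02 log units; within the scatter) in this assay and so no readable change. This position, ortho to a trifluoromethyl group, therefore accepts one added chlorine without a measurable shift in total growth inhibition. Nothing here offers an explanation for this result.

An amine or a carboxylic acid at the same position could still behave differently from chloro. The compounds shown also leave open whether the same chloro would have a similar effect on compound 1.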